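Thioether pyrimidine anilines: nitro to cyano at the ketone ring

A few compounds are considered here, and "the series" means these few. Any claim that something is new, unique, unknown or untested is made for them only; others in the source may bear on it.

Compound 1, `CC(=O)c1cccc(Nc2ccnc(SCC(=O)c3ccc(-c4ccccc4)cc3)n2)c1`: in a functional assay on IGROV-1 cells (Homo sapiens) for inhibition, read by sulforhodamine B assay, with a stated time of 48 h, tested at 10 uM (a lower number here means less inhibition of growth, a higher number more inhibition of growth at the concentration tested), compound 1 gives 20%.
Compound 2, `CCOC(=O)c1ccc(Nc2ccnc(SCC(=O)c3ccc([N+](=O)[O-])cc3)n2)cc1`: in this assay compound 2 gives 19%.
Compound 3, `CC(=O)c1ccc(Nc2ccnc(SCC(=O)c3ccc(Br)cc3)n2)cc1`: in this assay compound 3 gives 12%.

All three numbers lie within the usual scatter of one another, so none of the three can be set apart. Compound 2 sits among them, with compound 1 nearest and compound 3 furthest, both gaps inside the scatter. For the measured compounds named here, no single-point step between measured compounds is available to guide the next change.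

Compound 4, `CCOC(=O)c1ccc(Nc2ccnc(SCC(=O)c3ccc(C#N)cc3)n2)cc1`, is not yet measured in this assay. It differs from compound 2 in one place: cyano in place of nitro on an aromatic carbon. The three measured compounds carry a biphenyl, a nitro and a bromo group at the same ring and yet read alike, so the nitro to cyano exchange is expected to give a step of a number 1 percentage points lower from compound 2 to compound 4 (within the scatter), which is no step beyond the scatter in either direction. Compound 4 is therefore expected to read 18% in this assay, with a range from 5% to 32%.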

Compound 4, percent growth inhibition at one concentration: 21%
The estimate for compound 4 lay 3 percentage points below the measured number, and the stated range covers the measured number.
By their numbers in this assay, from the lowest: compounds 3, 2, 1 and 4 (each within the scatter of the next).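

For the compounds shown here, the exchange of nitro for cyano gives the first comparison in which only one place differs: in this assay the step is a number 2 percentage points higher from compound 2 to compound 4 (within the scatter). Going by these compounds alone, on this aromatic carbon, para to a large group, the two groups cannot be told apart, and the earlier compounds could not show this because each differed from the others in more than one place. Nothing measured here accounts for this reading.

As far as these compounds go, whether a carboxylic acid or an amine on this same carbon, or a longer chain in place of the ethyl of the ester, would give a step beyond the scatter remains open. From the compounds shown here alone, it also remains open whether cyano in place of nitro reads the same when the aniline carries the acetyl group of compound 3.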